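The source may report more compounds than this note shows. Statements on the series, on what has been measured and on what is new or still open speak of the compounds shown alone.

Compound 1, `O=C1c2ccccc2N(Cc2cccc(Cl)c2)S(=O)(=O)N1Cc1ccccc1`: > 5000 nM
Compound 2, `O=C1c2ccccc2N(Cc2ccccc2Cl)S(=O)(=O)N1COCc1ccccc1`: 200000 nM

In a functional assay on HEL cells (Homo sapiens) (a higher number here means that more compound is tolerated, a lower number that less compound is tolerated), compound 1 gives > 5000 nM, which is a limit of the assay rather than a number; this is the limit of > 5000 nM in this assay, at which 1 of the 2 values shown sits. Compound 2 gives 200000 nM in this assay. Compound 3, `C#CCOCN1c2ccccc2C(=O)N(Cc2ccccc2)S1(=O)=O`, is not yet measured. It differs from compound 1 by propargyloxy in place of 3-chlorophenyl on a saturated chain carbon bound to a sulfonamide nitrogen in a ring. Among the measured compounds shown here, no measured pair of this kind exists, so the step that the limit leaves unreadable from compound 1 to compound 3 is an expectation only, drawn from compound 2 at 200000 nM as the one numbered value of a related ether. Compound 3 is expected to reach 100000 nM, within 20000 nM to 400000 nM.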

Compound 3, minimum cytotoxic concentration: 140000 nM
Compound 3: the middle estimate sits 1.4-fold (0.15 log units) below what was measured, within the range that was stated.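

The step from compound 1 to compound 3 cannot be read, because the value of compound 1 is a limit of the assay and not a number: the limit of > 5000 nM in this assay, at which 1 of the 3 values shown sits. The compounds shown leave open how far propargyloxy in place of 3-chlorophenyl shifts the minimum cytotoxic concentration.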